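Trimming the tert-butyl group: what to expect

The compounds below may be only part of what the source reports. "The series", "measured", "known", "first", "only" and "open" are said of these compounds alone.

Compound 3 `CCCCOC(=O)NS(=O)(=O)c1ccc(CCC)cc1-c1ccc(Cn2c(C(C)(C)C)nc3ccccc32)cc1` gives 5.3 nM in an assay on membranes from HEK293 cells for displacement of a labelled ligand from Type-2 angiotensin II receptor (Homo sapiens), read by radioligand binding (a higher number here means a weaker inhibitor, a lower number a stronger inhibitor), the lowest of the three numbers shown. Compound 1 `CCCCOC(=O)NS(=O)(=O)c1ccc(CCC)cc1-c1ccc(Cn2c(C3CCCC3)nc3ccccc32)cc1` gives 35 nM and compound 2 `CCCCOC(=O)NS(=O)(=O)c1ccc(CCC)cc1-c1ccc(Cn2c(Cc3ccccc3)nc3ccccc32)cc1` gives 15 nM; both lie beyond the scatter above compound 3, with a 6.6-fold lower number from compound 1 to compound 3 (0.82 log units; beyond the scatter), a 2.8-fold lower number from compound 2 to compound 3 (0.45 log units; beyond the scatter) and a 2.3-fold lower number from compound 1 to compound 2 (0.37 log units; beyond the scatter). Compound 4 `CCCCOC(=O)NS(=O)(=O)c1ccc(CCC)cc1-c1ccc(Cn2c(CC)nc3ccccc32)cc1` differs from compound 3 by ethyl in place of tert-butyl on an aromatic carbon. The measured steps all exchange one large group for another at this aromatic carbon, and none replaces a group with a smaller one, so they bear only loosely on this change. Since tert-butyl gives the strongest number seen, a smaller group is expected to cost some potency in this assay, with wide uncertainty. Compound 4 is therefore expected to give 12 nM (range 4 nM to 40 nM), a step of a 2.3-fold higher number from compound 3 to compound 4 (0.35 log units; beyond the scatter).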

Compound 4, inhibition constant: 11 nM
Estimate against measurement, compound 4: 1.1-fold (0.04 log units) above; the range from low to high includes it.
By their numbers in this assay, from the lowest: compound 3; then compounds 4 and 2 (each within the scatter of the next); then compound 1.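

Ethyl, the first small group seen on this aromatic carbon between two ring nitrogen atoms, keeps most of the binding in this assay and costs only a modest step (a 2.1-fold higher number from compound 3 to compound 4 (0.32 log units; beyond the scatter)). The number therefore does not follow heavy atom count: ethyl still improves on cyclopentyl (a 3.2-fold lower number from compound 1 to compound 4 (0.50 log units; beyond the scatter)) and cannot be told apart from benzyl (a 1.4-fold lower number from compound 2 to compound 4 (0.13 log units; within the scatter)), while tert-butyl remains ahead of all three. Nothing available explains this order.

As far as these compounds go, whether methyl or a lone hydrogen would hold this level remains open, as does the effect of an amine or a carboxylic acid at this carbon.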